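This account rests on a few compounds, and the source may have more. Where it says the series, first, only, none or still open, it means among the compounds named here.

Measured compounds:
compound 1 `CN1[C@@H]2c3[nH]c4ccccc4c3C[C@H]1[C@H](C#N)N1[C@@H](CNC(=O)c3ccc(Cl)cc3)c3[nH]c4ccccc4c3C[C@@H]21` — 110 nM
compound 2 `CN1[C@@H]2c3[nH]c4ccccc4c3C[C@H]1[C@H](C#N)N1[C@@H](CNC(=O)c3ccc4ccccc4c3)c3[nH]c4ccccc4c3C[C@@H]21` — 1110 nM

In a functional assay on BGC-823 cells (Homo sapiens) for cytotoxicity, read by MTT assay, with a stated time of 72 h (on this read-out lower numbers stand for stronger inhibition and higher numbers for weaker inhibition), compound 2 gives the highest of the two numbers; compound 1 stands at the lower one, and the step of a 10-fold higher number from compound 1 to compound 2 (1.00 log units; beyond the scatter) separates them. Compound 3 `CN1[C@@H]2c3[nH]c4ccccc4c3C[C@H]1[C@H](C#N)N1[C@@H](CNC(=O)/C=C/c3ccccc3)c3[nH]c4ccccc4c3C[C@@H]21` keeps the shared core and the amide and carries the change (2-phenylethenyl in place of naphthalen-2-yl on a carbonyl carbon). Within the data shown here, no measured pair shows this exact replacement; only the exchange of aryl groups on the carbonyl in a 10-fold higher number from compound 1 to compound 2 (1.00 log units; beyond the scatter) bears on it, and it shows that such a swap can move the number well beyond the scatter. For compound 3 a lower number than compound 2 is expected, a 2.8-fold lower number from compound 2 to compound 3 (0.44 log units; beyond the scatter), with an estimate of 400 nM and a range from 100 nM to 1600 nM.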

Compound 3, half-maximal inhibitory concentration: 4300 nM
Compound 3: the middle estimate sits 11-fold (1.03 log units) below what was measured; measured number outside the range, above it.
By their numbers in this assay, from the lowest: compound 1; then compound 2; then compound 3.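

In this assay, the new group on the carbonyl carbon moves the number further up, with a 3.9-fold higher number from compound 2 to compound 3 (0.59 log units; beyond the scatter) for the loss of naphthalen-2-yl and a 39-fold higher number from compound 1 to compound 3 (1.59 log units; beyond the scatter) for the loss of 4-chlorophenyl, so this position spreads the three compounds widely. The count of aromatic rings does not order them: compound 1 and compound 3 each carry one such ring yet stand at opposite ends, with compound 2 and its two rings in the middle. Nothing shown gives a reason for this order.

Whether the chlorine or the double bond accounts for the gap stays open. A plain phenyl or a saturated 2-phenylethyl group on the same carbonyl would bear on that.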